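The compounds below may be only part of what the source reports. "The series", "measured", "known", "first", "only" and "open" are said of these compounds alone.

Values measured in an ADME assay on the whole organism (strain S2) for cytotoxicity, with Drosophila as the target, read by WST assay (on this read-out lower numbers stand for higher toxicity in this test and higher numbers for lower toxicity in this test), are as follows.

compound 1 `CCCCCCCC(=O)c1c(OC)c(Cl)c(OC)c(Cl)c1OC` gives 51400 nM
compound 2 `CCCCCC(=O)c1c(O)c(Cl)c(C)c(Cl)c1O` gives 13800 nM
compound 3 `CCCCCC(=O)c1c(O)cc(OC)c(Cl)c1O` gives 8700 nM

Compound 1 has the highest number of the three in this assay and stands apart from both other measured compounds by more than the scatter. The next entry for this series, compound 4 `CCCCCC(=O)c1c(OC)c(Cl)c(OC)c(Cl)c1OC`, has not yet been measured. Its change from compound 1 is hydrogen in place of ethyl on a saturated chain carbon, five bonds along the chain from a carbonyl carbon and can be summed up as hydrogen in place of ethyl on a saturated chain carbon, five bonds along the chain from a carbonyl carbon.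

Going by the values given here, no measured pair isolates this change. Compound 2 gives 13800 nM and compound 3 gives 8700 nM in this read-out, but each differs from compound 1 in more than one place, so neither number can be assigned to the change alone. They offer only a weak hint of the direction. A modest step to a lower number is expected, with a step beyond the scatter in either direction not excluded. The estimated step of a 1.5-fold lower number from compound 1 to compound 4 (0.17 log units; within the scatter) would most likely stay within the scatter. For compound 4 the expected value is 35000 nM, with an estimated range of 14000 nM to 90000 nM in the measurement still to come.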

Compound 4, half-maximal cytotoxic concentration: 148000 nM
Compound 4: the middle estimate sits 4.2-fold (0.63 log units) below what was measured; the whole stated range lies below it.
By their numbers in this assay, from the lowest: compounds 3 and 2 (each within the scatter of the next); then compound 1; then compound 4.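

Hydrogen in place of ethyl on a saturated chain carbon, five bonds along the chain from a carbonyl carbon, gives the series its first isolated change: in this assay the step is a 2.9-fold higher number from compound 1 to compound 4 (0.46 log units; beyond the scatter) on an otherwise unchanged core. The step is modest but beyond the scatter, so the outer part of this chain has a readable influence on the result in this test, and the shorter chain goes with lower toxicity in this test. Nothing measured here bears on why the read-out moves in this direction.

On these data alone, a single pair fixes no trend with chain length, so it remains open whether a longer chain, a branched chain, or a chain ending in an amine or a carboxylic acid would continue this direction, reverse it, or leave the read-out within the scatter. As far as these compounds go, it also remains open whether the same change in the chain would give a step of similar size and direction on a core carrying hydroxyl groups in place of the methoxy groups of compound 1.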